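The source may hold more compounds than are shown below. What is called first, only, known or untested is meant among the compounds shown, and "the series" means these compounds.

Measured compounds in a functional assay on cells for antagonist activity at Free fatty acid receptor 1 (Homo sapiens), read by TR-FRET and inositol phosphate accumulation, with a stated time of 2 h; a higher number here means a weaker inhibitor, a lower number a stronger inhibitor:
compound 1, `CC(=O)Nc1ccc(OCc2cc(C)nc(-c3ccccn3)n2)cc1` — only a limit, > 39800 nM
compound 2, `CC(C)Nc1cc(COc2cccc(F)c2)nc(-c2ccccn2)n1` — 100 nM
compound 3, `OC1CN(c2cc(COc3ccc(F)c(F)c3F)nc(-c3ccccn3)n2)C1` — 3160 nM

Compound 3 holds the highest of the two numbers shown in this assay, at 3160 nM. Compound 2 sits at 100 nM, a lower number that lies beyond the scatter of the method. For compound 1 this assay returns no number but a limit, > 39800 nM; this is the limit of > 39800 nM in this assay, at which 1 of the 3 values shown sits. No pair among these three differs in one place only, so no single measured step can be stated.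

Compound 4, `N#CCC1(COc2cc(COc3ccc(F)c(F)c3F)nc(-c3ccccn3)n2)COC1`, is the next compound of the series and has not yet been measured. It differs from compound 3 by (3-(cyanomethyl)oxetan-3-yl)methoxy in place of 3-hydroxyazetidin-1-yl on an aromatic carbon. Among the measured compounds shown here, with no measured step of this kind to lean on, the direction of the change cannot be read from the data; a step of modest size, in either direction, is expected. Compound 4 is estimated at 2500 nM in this assay, within 500 nM to 12000 nM. That estimate means a step of a 1.3-fold lower number from compound 3 to compound 4 (0.10 log units; within the scatter), expected to stay close to the scatter.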

Compound 4, half-maximal inhibitory concentration in the Free fatty acid receptor 1 assay: 398 nM
For compound 4 the middle estimate is 6.3-fold (0.80 log units) above the measured one; the measured number lies below the stated range.
By their numbers in the Free fatty acid receptor 1 assay, from the lowest: compound 2; then compound 4; then compound 3. At a limit, above all of these: compound 1.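

In the Free fatty acid receptor 1 assay, (3-(cyanomethyl)oxetan-3-yl)methoxy in place of 3-hydroxyazetidin-1-yl on this aromatic carbon gives a 7.9-fold lower number from compound 3 to compound 4 (0.90 log units; beyond the scatter). This position therefore accepts the larger group, and the hydrogen-bond donor of 3-hydroxyazetidin-1-yl is not required for the lower number seen here. In a physicochemical assay for lipophilicity, at pH 7.4 (on this read-out lower numbers stand for lower lipophilicity and higher numbers for higher lipophilicity), compound 3 gives 2.8 and compound 4 gives 3.3. The same change also comes with higher measured lipophilicity in the physicochemical assay: the measured distribution coefficient of compound 3, 2.8, and of compound 4, 3.3, a number 0.50 log units higher (beyond the scatter)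

The change swaps the ring, the attachment and the nitrile-bearing arm together, so the compounds shown cannot assign the step to any one of these parts, or say how much of it tracks with lipophilicity. A plain methoxy group, or an oxetan-3-ylmethoxy group without the cyanomethyl arm, at the same position would separate these contributions.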